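Working notes: aryl group swap on the ring nitrogen

The source may report more compounds than this note shows. Statements on the series, on what has been measured and on what is new or still open speak of the compounds shown alone.

Measured compounds, all in a functional assay on CHO cells with adenosine receptor A1 (Homo sapiens) as the target, read by cAMP accumulation and immunoassay, with a stated time of 6 min, tested at 0.1 uM; a higher number here means a weaker effect of the compound at the concentration tested, a lower number a stronger effect:

compound 1 `Nc1scc(CN2CCN(c3c(F)cc(F)cc3F)CC2)c1C(=O)c1ccc(Cl)cc1` gives -3.9%
compound 2 `Nc1scc(CN2CCN(c3ccccc3Cl)CC2)c1C(=O)c1ccc(Cl)cc1` gives 2%
compound 3 `Nc1scc(CN2CCN(c3cc(Cl)ccc3Cl)CC2)c1C(=O)c1ccc(Cl)cc1` gives -6.2%

Compound 3 has the lowest of the three numbers, but its nearest neighbour, compound 1, stands a number 2.3 percentage points lower from compound 1 to compound 3 (within the scatter), and compound 2 stands a number 8.2 percentage points lower from compound 2 to compound 3 (within the scatter); both steps lie within the scatter, so no ordering among the three can be read. The step of a number 5.9 percentage points higher from compound 1 to compound 2 (within the scatter) is likewise within the scatter.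

Compound 4 `Nc1scc(CN2CCN(c3ccc(Cl)c(Cl)c3)CC2)c1C(=O)c1ccc(Cl)cc1` is not yet measured. It differs from compound 3 only on the ring nitrogen: 3,4-dichlorophenyl in place of 2,5-dichlorophenyl on an amine nitrogen in a ring. For the measured compounds named here, the steps that bear on this change are those that vary the aryl group on the same ring nitrogen, compounds 1, 2 and 3, and each of them sits within the scatter. Going by the values given here, nothing among the measured compounds indicates that the aryl group on this nitrogen moves the read-out, so for compound 4 no step beyond the scatter is expected in either direction; the estimated step is a number 3.2 percentage points higher from compound 3 to compound 4 (within the scatter). Compound 4 is therefore expected to give about -3%, with a range from -13% to 7%.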

Compound 4, a percentage reported as activity, at one concentration (the size of the read-out at that concentration, not a potency): -13%
Compound 4: the middle estimate sits 10 percentage points above what was measured; measured number inside the range.
By their numbers in this assay, from the lowest: compounds 4, 3, 1 and 2 (each within the scatter of the next, the first and the last beyond it).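

In this assay, rearranging the same atoms from 2,5-dichlorophenyl to 3,4-dichlorophenyl gives a number 6.8 percentage points lower from compound 3 to compound 4 (within the scatter), so this change cannot be read as moving the read-out, and the change from the trifluorophenyl group gives a number 9.1 percentage points lower from compound 1 to compound 4 (within the scatter) and cannot be read either. The aryl group on the ring nitrogen now gives its first step outside the noise, a number 15 percentage points lower from compound 2 to compound 4 (beyond the scatter), which is modest and shows that this position can move the read-out, although compounds 1 and 3 stand within the scatter of both ends and so do not form a graded trend. This change alters both the number and the placement of the chloro groups, the contribution of each cannot be separated, and no supporting data are available to explain the step.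

The compounds shown leave open whether the read-out at this position depends on halogens at all, since a methoxy group, an amine or a carboxylic acid on the phenyl ring would test that directly. They also leave open whether the phenyl ring itself is needed, which a pyridine ring or a simple alkyl chain on the ring nitrogen would address.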